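Ring Size of the Basic Amine in Two Related Series

The source may report more compounds than this note shows. Statements on the series, on what has been measured and on what is new or still open speak of the compounds shown alone.

Compound 1 `COc1cc2c(Oc3ccc(NC(=O)c4nnn(-c5ccccc5)c4C)cc3F)ccnc2cc1OCCCN1CCCC1` and compound 3 `COc1cc2c(Oc3ccc(NC(=O)c4nnn(-c5ccccc5)c4C)cc3F)ccnc2cc1OCCCN1CCCCC1` share one core and differ only by piperidin-1-yl in place of pyrrolidin-1-yl on a saturated chain carbon, three bonds along the chain from an oxygen on an aromatic ring. In a functional assay on MKN-45 cells (Homo sapiens) for cytotoxicity, read by MTT assay, with a stated time of 72 h (a higher number here means a weaker inhibitor, a lower number a stronger inhibitor), compound 1 gives 40 nM, while compound 3 gives 80 nM; the change amounts to a 2.0-fold higher number from compound 1 to compound 3 (0.30 log units; within the scatter). Compound 2 `COc1cc2c(Oc3ccc(NC(=O)c4nnn(-c5ccc(F)cc5)c4C(F)(F)F)cc3F)ccnc2cc1OCCCN1CCCC1` is built on a second core; the difference between the two cores is not broken down here. In this assay compound 2 gives 21 nM. Compound 4 `COc1cc2c(Oc3ccc(NC(=O)c4nnn(-c5ccc(F)cc5)c4C(F)(F)F)cc3F)ccnc2cc1OCCCN1CCCCC1` has not yet been measured and arises from compound 2 through the same change, (piperidin-1-yl in place of pyrrolidin-1-yl on a saturated chain carbon, three bonds along the chain from an oxygen on an aromatic ring). Among the compounds with values here, because the only measured example of this change gave a 2.0-fold higher number from compound 1 to compound 3 (0.30 log units; within the scatter), a step of similar size is expected here, a 1.9-fold higher number from compound 2 to compound 4 (0.28 log units; within the scatter), with no second example to sharpen the guess. Compound 4 is therefore estimated at 40 nM, likely between 18 nM and 90 nM.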

Compound 4, half-maximal inhibitory concentration: 40 nM
For compound 4 middle estimate and measured number coincide at the digits printed; the measured number falls inside the stated range.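

Replacing pyrrolidin-1-yl with piperidin-1-yl on the core of compound 2 gives, in this assay, a 1.9-fold higher number from compound 2 to compound 4 (0.28 log units; within the scatter). Set beside the earlier step, the change carries over between the two cores with no readable difference in size: the same change on two cores in this assay, a 2.0-fold higher number (0.30 log units; within the scatter) from compound 1 to compound 3 and a 1.9-fold higher number (0.28 log units; within the scatter) from compound 2 to compound 4, 1.1-fold (0.02 log units) apart, within the scatter of two such steps. Each step on its own lies within the scatter, so this agreement does not establish a real loss of potency with piperidin-1-yl, and it says nothing about any further core.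

The compounds shown leave open how a morpholine or a dimethylamino group would read at the end of the chain, and how a longer chain would read. Also open, as far as these compounds go, is what the trifluoromethyl group and the fluorine on the core of compound 2 each contribute separately.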